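Moving the methyl on the N-aryl ring of the bile acid receptor agonist

This account rests on a few compounds, and the source may have more. Where it says the series, first, only, none or still open, it means among the compounds named here.

Measured so far:
compound 1, `CCc1ccccc1-n1nc(C)c2c1NC(=O)[C@H](C)S[C@@H]2c1ccc(Oc2ccccc2)cc1`, 190%
compound 2, `Cc1ccccc1-n1nc(C)c2c1NC(=O)[C@H](C)S[C@@H]2c1ccc(-c2ccco2)cc1`, 32%
compound 3, `Cc1nn(-c2ccccc2Br)c2c1C(c1ccc(Oc3ccccc3)cc1)SC(C)C(=O)N2`, 84%

Of the compounds shown here, three sharing one core have been tested in an assay on isolated protein for agonist activity at Bile acid receptor (Homo sapiens), read by AlphaScreen, with a stated time of 30 min; on this read-out higher numbers stand for larger maximal responses and lower numbers for smaller maximal responses. Compound 1 gives 190%, the highest of the three; the gaps to compound 3 and to compound 2 both lie beyond the usual scatter. Compound 3 combines a bromophenyl on the ring nitrogen with the phenoxy group and reaches 84%, while compound 2 carries a furanyl in place of the phenoxy and reaches 32%.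

The next compound, compound 4, `Cc1cccc(-n2nc(C)c3c2NC(=O)[C@H](C)S[C@@H]3c2ccc(Oc3ccccc3)cc2)c1`, differs from compound 1 in one place: 3-methylphenyl in place of 2-ethylphenyl on an aromatic nitrogen. Among the compounds with values here, no pair of measured compounds isolates this change, so its effect is not known from the data. Compound 3 shows that another group on this ring nitrogen goes with a smaller maximal response than that of compound 1, so a drop is expected rather than a gain. For compound 4 the expected step is a number 80 percentage points lower from compound 1 to compound 4 (beyond the scatter), a decrease beyond the scatter. Compound 4 is estimated at 110%, with a range from 50% to 180%.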

Compound 4, largest response reached (reported as efficacy), in percent of the reference or control that the assay uses: 22%
Compound 4: the middle estimate sits 88 percentage points above what was measured; the measured number lies below the stated range.
By their numbers in this assay, from the lowest: compounds 4 and 2 (each within the scatter of the next); then compound 3; then compound 1.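

Within the data shown here, the pair gives the first direct reading of the group on this aromatic nitrogen: in this assay, 3-methylphenyl in place of 2-ethylphenyl gives a number 168 percentage points lower from compound 1 to compound 4 (beyond the scatter), with the rest of the molecule unchanged. Both groups have one six-membered aromatic ring of carbon only, no hydrogen-bond donors or acceptors and no net charge, so the large step arises without any difference in those counted features. Nothing measured on these compounds accounts for the step.

The swap alters both the alkyl chain and its place on the phenyl ring, and the compounds shown do not separate the two. Also open, from the compounds shown here alone, is how 3-ethylphenyl, an unsubstituted phenyl or 2-methoxyphenyl on this nitrogen would behave alongside the phenoxy group of compound 1.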